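A Phenyl-to-Cyclopropyl Swap and Its Expected Cost

The source may report more compounds than this note shows. Statements on the series, on what has been measured and on what is new or still open speak of the compounds shown alone.

Of the compounds shown here, three built on a shared fused core have been measured in a functional assay on MCF7 cells (Homo sapiens) for inhibition, read by fluorescence, with a stated time of 72 h; a lower number here means a stronger inhibitor of growth, a higher number a weaker inhibitor of growth. Compound 2 `Cc1nc(-c2ccccc2)cc2nn(-c3ccccc3)cc12` gives 11000 nM. Compound 1 `Cc1nc(C2CC2)cc2nn(-c3ccccc3)cc12` carries one change relative to compound 2, namely (cyclopropyl in place of phenyl on an aromatic carbon), and in this assay compound 1 gives 63500 nM, a step of a 5.8-fold higher number from compound 2 to compound 1 (0.76 log units; beyond the scatter). Compound 3 `c1ccc(-c2cc3nn(-c4ccccc4)cc3cn2)cc1` differs from compound 2 in another way, (hydrogen in place of methyl on an aromatic carbon), and in this assay compound 3 gives 4800 nM, a step of a 2.3-fold lower number from compound 2 to compound 3 (0.36 log units; beyond the scatter). Of the three, compound 3 has the lowest number, and its steps to both other compounds lie beyond the scatter.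

Compound 4 `c1ccc(-n2cc3cnc(C4CC4)cc3n2)cc1` has not yet been measured. It differs from compound 3 by cyclopropyl in place of phenyl on an aromatic carbon. Within the data shown here, this is the same kind of change as the one from compound 2 to compound 1, although the surroundings are not identical: in compound 2 the place is also meta to a methyl group (1 heavy atom), whereas in compound 3 that methyl has been replaced by hydrogen. Because the earlier step of a 5.8-fold higher number from compound 2 to compound 1 (0.76 log units; beyond the scatter) was a clear weakening, a weakening of similar size is expected here as well, with some allowance for the differing surroundings. Compound 4 is therefore expected to show a step of a 5.8-fold higher number from compound 3 to compound 4 (0.77 log units; beyond the scatter). Compound 4 is estimated at 28000 nM, with a likely range from 12000 nM to 65000 nM.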

Compound 4, concentration for 50% growth inhibition: 69300 nM
For compound 4 the middle estimate is 2.5-fold (0.39 log units) below the measured one; the whole stated range lies below it.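

In this assay, cyclopropyl in place of phenyl again gives a weaker inhibitor of growth, a 14-fold higher number from compound 3 to compound 4 (1.16 log units; beyond the scatter), so the change carries over in direction, and the two steps do not differ in size by more than the scatter expected when two such steps are compared: the same change on two cores in this assay, a 5.8-fold higher number (0.76 log units; beyond the scatter) from compound 2 to compound 1 and a 14-fold higher number (1.16 log units; beyond the scatter) from compound 3 to compound 4, 2.5-fold (0.40 log units) apart, within the scatter of two such steps. The companion change, hydrogen in place of methyl, gives a 1.1-fold higher number from compound 1 to compound 4 (0.04 log units; within the scatter), which cannot be told from no change on the cyclopropyl pair, yet this step and its counterpart on the phenyl pair also stay within that scatter of each other: the same change on two cores in this assay, a 2.3-fold lower number (0.36 log units; beyond the scatter) from compound 2 to compound 3 and a 1.1-fold higher number (0.04 log units; within the scatter) from compound 1 to compound 4, 2.5-fold (0.40 log units) apart, within the scatter of two such steps. These four compounds therefore support treating the loss from the phenyl-to-cyclopropyl swap as roughly shared by the two cores, but they do not show that the loss truly grows on the core without methyl, that it would hold on any further core, or why it occurs.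

The compounds shown carry only phenyl or cyclopropyl at this place, so it remains open how an amine, a carboxylic acid or a longer chain would behave there. Going by these compounds, the other phenyl is the same in all four compounds, and what replacing it would do to these steps also stays open.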